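A few compounds are considered here, and "the series" means these few. Any claim that something is new, unique, unknown or untested is made for them only; others in the source may bear on it.

Compound 1 `O=C(COc1ccc2cc(/C=C3/SC(=O)NC3=O)ccc2c1)Nc1cc(Cl)cc(C(F)(F)F)c1`: 4000 nM
Compound 2 `O=C(COc1ccc2cc(/C=C3/SC(=O)NC3=O)ccc2c1)Nc1ccc(Br)cc1F`: 1900 nM
Compound 3 `Cc1cc(Br)ccc1NC(=O)COc1ccc2cc(/C=C3/SC(=O)NC3=O)ccc2c1`: 550 nM

In an assay on isolated protein for inhibition of histone deacetylase 4 (Homo sapiens), with a stated time of 1 h (on this read-out lower numbers stand for stronger inhibition and higher numbers for weaker inhibition), compound 1 gives the highest number of the three; compound 2 lies nearest to it and compound 3 furthest from it. Compound 4 `O=C(COc1ccc2cc(/C=C3/SC(=O)NC3=O)ccc2c1)Nc1ccc(Cl)c(Cl)c1` differs from compound 1 by 3,4-dichlorophenyl in place of 3-chloro-5-(trifluoromethyl)phenyl on an amide-type nitrogen. Two measured steps, each exchanging that same group on the amide-type nitrogen, bear on this change: a 2.1-fold lower number from compound 1 to compound 2 (0.32 log units; beyond the scatter) and a 7.3-fold lower number from compound 1 to compound 3 (0.86 log units; beyond the scatter). Both moved the number downward beyond the scatter, although the entering groups differed in their pattern of halogens and methyl. A modest downward step is therefore expected for this exchange as well, of the size a 2.2-fold lower number from compound 1 to compound 4 (0.35 log units; beyond the scatter). Compound 4 is estimated at 1800 nM, with a range from 700 nM to 5000 nM.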

Compound 4, half-maximal inhibitory concentration: 5500 nM
The estimate for compound 4 lay 3.1-fold (0.49 log units) below the measured number, and the stated range ends below it.
By their numbers in this assay, from the lowest: compound 3; then compound 2; then compounds 1 and 4 (each within the scatter of the next).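

Not every exchange of the group on the amide-type nitrogen lowers the number in this assay: 3,4-dichlorophenyl in place of 3-chloro-5-(trifluoromethyl)phenyl stays within the scatter, with a 1.4-fold higher number from compound 1 to compound 4 (0.14 log units; within the scatter). The same 3,4-dichlorophenyl group gives higher numbers than the other two groups, with a 2.9-fold higher number from compound 2 to compound 4 (0.46 log units; beyond the scatter) and a 10-fold higher number from compound 3 to compound 4 (1.00 log units; beyond the scatter), so the lower numbers belong to those two groups and not to the exchange as such. Nothing measured here offers a reason for this.

Going by these compounds, it remains open how a phenyl group carrying a methoxy group or an amine would read on this nitrogen, and how a pyridine ring would read there.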